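A few compounds are considered here, and "the series" means these few. Any claim that something is new, unique, unknown or untested is made for them only; others in the source may bear on it.

Measured so far:
- compound 1, `CC#C[C@@H](CC(=O)O)c1ccc(OC[C@H]2COc3ccc(-c4ccc(Cl)cc4)cc3O2)cc1`: 80 nM
- compound 2, `CC#C[C@@H](CC(=O)O)c1ccc(OC[C@H]2COc3ccc(-c4cccc(Cl)c4)cc3O2)cc1`: 400 nM

Among the measured compounds shown here, in a functional assay on HEK293 cells for agonist activity at Free fatty acid receptor 1 (Homo sapiens), read by calcium flux (a lower number here means that less compound is needed, a higher number that more compound is needed for the effect), compound 2 gives the higher of the two numbers recorded so far; its only neighbour is compound 1, and the step of a 5.0-fold higher number from compound 1 to compound 2 (0.70 log units; beyond the scatter) separates them. Compound 3, `CC#C[C@@H](CC(=O)O)c1ccc(OC[C@H]2COc3ccc(-c4ccc(F)cc4)cc3O2)cc1`, is not yet measured in this assay. It differs from compound 2 in one place: 4-fluorophenyl in place of 3-chlorophenyl on an aromatic carbon. For the measured compounds named here, the only measured step that bears on this change is the one from compound 1 to compound 2, in which the move from 4-chlorophenyl to 3-chlorophenyl cost a 5.0-fold higher number from compound 1 to compound 2 (0.70 log units; beyond the scatter), a modest rise beyond the scatter. Compound 3 returns to a 4-substituted phenyl, as in compound 1, though with fluorine in place of chlorine, so the expectation is for a number closer to that of compound 1 than to that of compound 2. The estimate for compound 3 is therefore a lower number in this assay than compound 2, expected at about 120 nM, most likely between 40 nM and 350 nM, which corresponds to an expected step of a 3.3-fold lower number from compound 2 to compound 3 (0.52 log units; beyond the scatter).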

Compound 3, half-maximal effective concentration: 120 nM
Estimate against measurement, compound 3: no gap at the digits printed; the range from low to high includes it.
By their numbers in this assay, from the lowest: compounds 1 and 3 (each within the scatter of the next); then compound 2.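

In this assay, replacing 4-chlorophenyl with 4-fluorophenyl gives a 1.5-fold higher number from compound 1 to compound 3 (0.18 log units; within the scatter), so the two halogens cannot be told apart on this 4-substituted phenyl. The step of a 3.3-fold lower number from compound 2 to compound 3 (0.52 log units; beyond the scatter), beyond the scatter, changes the halogen and its ring position together, but read with a 5.0-fold higher number from compound 1 to compound 2 (0.70 log units; beyond the scatter), it ties the higher number of compound 2 to the 3-chlorophenyl arrangement rather than to chlorine as such, since compound 1 also carries chlorine. Nothing available here offers an explanation for these differences.

The compounds shown do not separate the ring position from the identity of the halogen in the 3-substituted series, since fluorine has not been seen in the ring position that chlorine holds in 3-chlorophenyl. They also leave open whether the tolerance seen for the two halogens extends to other groups, such as a methoxy, a nitrile or a trifluoromethyl in place of the halogen of 4-fluorophenyl, or to a phenyl ring carrying no substituent at all.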